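Inverting one stereocentre of compound 1

The source may report more compounds than this note shows. Statements on the series, on what has been measured and on what is new or still open speak of the compounds shown alone.

Compound 1 `COC1=C(Br)[C@H](O)[C@@]2(C=C1Br)CC(C(=O)NCCCCNC(=O)C1=NO[C@]3(C=C(Br)C(=O)[C@@H](Br)[C@@H]3O)C1)=NO2` was examined in a functional assay on A549 cells (Homo sapiens) for cytotoxicity, read by sulforhodamine B assay; on this read-out lower numbers stand for higher toxicity in this test and higher numbers for lower toxicity in this test. There, compound 1 gives > 10 ug/mL, which is a limit of the assay and not a number. Compound 2 `COC1(OC)C(Br)=C[C@@]2(CC(C(=O)NCCCCCNC(=O)C3=NO[C@]4(C=C(Br)C(OC)(OC)[C@@H](Br)[C@@H]4O)C3)=NO2)[C@@H](O)[C@@H]1Br` gives > 10 ug/mL, also a limit of the assay. So the picture so far is the limit of > 10 ug/mL in this assay, at which 2 of the 2 values shown sit, and no exact number is available for either compound.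

Compound 3 `COC1=C(Br)[C@H](O)[C@@]2(C=C1Br)CC(C(=O)NCCCCNC(=O)C1=NO[C@]3(C=C(Br)C(=O)[C@H](Br)[C@@H]3O)C1)=NO2` is a close relative of compound 1: the two compounds have the same atoms and bonds and differ only in configuration as drawn: 1 of 5 stereo elements differ; a stereocentre at a saturated ring carbon is drawn S in compound 1 and R in compound 3. Among the compounds with values here, no measured pair shows what such an inversion does in this assay. The expectation therefore rests on compound 1 at > 10 ug/mL, a limit, and no shift beyond the usual scatter is expected. The estimated step is a step that the limit leaves unreadable from compound 1 to compound 3. For compound 3 the estimated value is 14 ug/mL, with an expected range from 6 ug/mL to 30 ug/mL.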

Compound 3, concentration lethal to 50% of the cells: > 10 ug/mL
Compound 3: no number, only a limit; the forecaster's own chance of this, stated with the estimate: 80%; the middle value does not contradict the limit.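

Compound 1 and compound 3 both sit at a limit of the assay and not at a number, so no step can be read between them. The compounds shown leave open whether inverting this one stereocentre changes the result in this assay at all.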